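The compounds below may be only part of what the source reports. "The series", "measured", "known", "first", "only" and "open" are said of these compounds alone.

Compound 1 `O=c1cc(I)n([C@@H]2O[C@H](CO)[C@@H](O)[C@H]2O)c(=O)[nH]1`: > 50000 nM, a limit
Compound 2 `O=c1[nH]c(=O)n([C@@H]2O[C@H](CO)[C@@H](O)[C@H]2O)c(I)c1F`: > 50000 nM, a limit

Both compounds were tested in a functional assay on LOX cells (Homo sapiens) for antiproliferative activity, read by WST assay, with a stated time of 3 days; on this read-out lower numbers stand for stronger inhibition and higher numbers for weaker inhibition. Compound 2 gives only a limit there, > 50000 nM, so no true number is known for it. Together the two compounds make up (the limit of > 50000 nM in this assay, at which 2 of the 2 values shown sit).

Compound 3 `O=Cc1c(F)c(=O)[nH]c(=O)n1[C@@H]1O[C@H](CO)[C@@H](O)[C@H]1O` differs from compound 2 in one place, with formyl in place of iodo on an aromatic carbon. For the measured compounds named here, the only measured step is a step that the two limits leave unreadable from compound 1 to compound 2, in which fluoro replaces hydrogen on an aromatic carbon. That step offers no size to carry over, and no measurement covers a change of iodo to formyl.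

Going by the values given here, the one starting point is compound 2 at > 50000 nM, a limit, so compound 3 is expected to remain weak in this assay. No clear step in either direction is expected, and another limit is quite likely. The estimated step is a number no higher from compound 2 to compound 3 (the limit leaves the size open). For compound 3 the expected value is 50000 nM. The estimated range for compound 3 runs from 8000 nM to 100000 nM.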

Compound 3, half-maximal inhibitory concentration: 400 nM
The estimate for compound 3 lay 130-fold (2.10 log units) above the measured number; measured number below the stated range.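

In this assay, the carbon next to the ring nitrogen and ortho to a fluoro group turns out to be a place where one change can bring out clear activity: formyl in place of iodo gives an at least 120-fold lower number from compound 2 to compound 3 (2.09 log units; beyond the scatter). The earlier compounds shown here could not show this, since the step between them cannot be read and neither gave a true number: the limit of > 50000 nM in this assay, at which 2 of the 3 values shown sit. For the compounds shown here, compound 3 supplies the first true number here, but its change swaps a single iodine for a group that brings a double bond and a hydrogen-bond acceptor, and this one pair cannot tell which of these features matters, or whether the loss of the iodine itself plays a part.

The compounds shown leave open whether the fluoro group is needed for this activity, as none of them pairs a formyl group with hydrogen on the neighbouring ring carbon. They also leave open how specific the formyl group is, since a hydroxymethyl group, an acetyl group, a nitrile or a carboxylic acid at the same position would each test a different part of that change.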